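The source may report more compounds than this note shows. Statements on the series, on what has been measured and on what is new or still open speak of the compounds shown alone.

In a functional assay on P388 cells (Mus musculus) for cytotoxicity (a higher number here means that more compound is needed for the effect, a lower number that less compound is needed), the measured compounds give:

Compound 1 `c1ccc(COc2cc(-c3ccccc3)nc3ccccc23)cc1` gives > 10 ug/mL
Compound 2 `Oc1ccc2nc(-c3ccccc3)cc(O)c2c1` gives 2.86 ug/mL

Compound 1 reads > 10 ug/mL in this assay and this is a limit of the assay, not a number. For the measured compounds named here, compound 2, at 2.86 ug/mL in the same test, therefore holds the only real number so far, so it has no measured neighbour to be ranked against.

The next compound to be tested is compound 3 `Oc1cc(-c2ccccc2)nc2ccc(Cl)cc12`. It keeps the core of compound 2 but has chloro in place of hydroxy on an aromatic carbon. Going by the values given here, no two measured compounds differ in one place only, so no measured step shows how large such a change tends to be. The best guide is the value of compound 2 at 2.86 ug/mL as a starting point. In this assay no step beyond the usual scatter is expected, with a slight lean toward a higher number. The estimated step is a 1.6-fold higher number from compound 2 to compound 3 (0.20 log units; within the scatter) as a cautious guess. For compound 3 the expected value is 4.5 ug/mL with an estimated range from 1.3 ug/mL to 13 ug/mL as its upper end.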

Compound 3, half-maximal effective concentration: 0.84 ug/mL
Compound 3: middle estimate off by 5.4-fold (0.73 log units), on the high side, and the stated range ends above it.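

For the compounds shown here, this is the first measured step. In this assay, putting chloro in place of hydroxy on an aromatic carbon gives a 3.4-fold lower number from compound 2 to compound 3 (0.53 log units; beyond the scatter), so less compound is needed for the effect. The hydroxy at this place is therefore not required for cytotoxicity in these cells, at least on this core, and this position can change the result by more than the usual scatter. The hydroxy carries a hydrogen-bond donor and acceptor while the chloro carries neither, but nothing measured here shows whether that difference or some other one lies behind the step.

This single pair gives one step at one position on one core, so it sets no general rule for the series. On these data alone, it remains open how other groups at this place, such as fluoro, bromo, methyl, methoxy or an amine, would compare with chloro, and whether replacing the other hydroxy, which compound 2 and compound 3 share, would move the number in the same direction.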